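A few compounds are considered here, and "the series" means these few. Any claim that something is new, unique, unknown or untested is made for them only; others in the source may bear on it.

The series is followed in an ADME assay on cells (Homo sapiens) for cytotoxicity, read by polymerase chain reaction, with a stated time of 3 days; a higher number here means that more compound is tolerated, a lower number that less compound is tolerated. Compound 1 `Nc1nc(Cl)c(-c2nccs2)c(N[C@@H]2C[C@H](CO)[C@@H](O)[C@H]2O)n1` sits at the edge of what the assay can report, giving > 25000 nM in this assay, which is a limit and not a number. Compound 2 `CCCNc1nc(C)c(-c2nc3ccccc3s2)c(N[C@@H]2C[C@H](CO)[C@@H](O)[C@H]2O)n1` likewise gives > 25000 nM in this assay, again a limit rather than a measured figure. Going by the values given here, both values shown therefore lie at the same place, (the limit of > 25000 nM in this assay, at which 2 of the 2 values shown sit), and no step between measured compounds that differ in one place exists to anchor a direction; compound 2 stands only at the limit it shares with compound 1.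

Compound 3 `Cc1nc(NCc2cccnc2)nc(N[C@@H]2C[C@H](CO)[C@@H](O)[C@H]2O)c1-c1nc2ccccc2s1` has not yet been measured. It differs from compound 2 in one place: pyridin-3-yl in place of ethyl on a saturated chain carbon bound to a nitrogen on an aromatic ring. Among the compounds with values here, the only guidance is that both measured compounds sit at the limit, so no step beyond the usual scatter is expected in this assay in either direction. Compound 3 is expected to give 30000 nM in this assay, between 12000 nM and 80000 nM. The step this estimate implies, a step that the limit leaves unreadable from compound 2 to compound 3, is expected to stay within scatter, and the most likely outcome is that the assay again returns only its limit.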

Compound 3, half-maximal cytotoxic concentration: 5000 nM
Compound 3: middle estimate off by 6.0-fold (0.78 log units), on the high side, outside the stated range (below it).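

In this assay, going by these compounds alone, pyridin-3-yl in place of ethyl on a saturated chain carbon bound to a nitrogen on an aromatic ring gives an at least 5.0-fold lower number from compound 2 to compound 3 (0.69 log units; beyond the scatter), the first readable change. This position is therefore not indifferent in this assay: the group carried there can decide whether the assay returns a limit or a number, which compound 2 alone could not show. Compound 2 gives a limit and not a number, so the step fixes only a lower bound on the change, and its true size stays unknown: the limit of > 25000 nM in this assay, at which 2 of the 3 values shown sit.

From the compounds shown here alone, whether the step follows the aromatic ring as such or its ring nitrogen stays open; a phenyl group at the same place would separate the two, and a longer chain would show whether a larger group without a ring does the same. Going by these compounds, with a single readable step, no trend can be drawn for this position, and whether the same change would have a similar outcome on a different core also remains unknown.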